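The source may report more compounds than this note shows. Statements on the series, on what has been measured and on what is new or still open speak of the compounds shown alone.

Of the compounds shown here, three have been measured in an assay on isolated protein for inhibition of ATP-citrate synthase (Rattus norvegicus); a higher number here means a weaker inhibitor, a lower number a stronger inhibitor. Compound 1 `O=C(O)CC(O)(CSCCCCCCc1cccc(Cl)c1Cl)C(=O)O` gives 7300 nM, compound 2 `O=C(O)CC(O)(CSCCCCCCc1ccc(Cl)c(Cl)c1)C(=O)O` gives 110000 nM, and compound 3 `O=C(O)CC(O)(CSCCCCCCc1ccc(-c2ccccc2)cc1)C(=O)O` gives 38000 nM. All three share the same core and the same saturated chain; they differ only in the aromatic ring at the chain's end. Among the compounds with values here, the one step that can be followed in one move is the move of the two chlorines around the ring, which gave a 15-fold higher number from compound 1 to compound 2 (1.18 log units; beyond the scatter). Compound 3 stands second highest of the three numbers: its value lies above that of compound 1 and below that of compound 2, both gaps beyond the scatter.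

Compound 4 `O=C(O)CC(O)(CSCCCCCCc1ccc(O)cc1)C(=O)O` takes the next step from compound 3: hydroxy in place of phenyl on an aromatic carbon. Within the data shown here, no measured step swaps one ring substituent for a different kind of group, so the step from compound 1 to compound 2 only shows that changes on this ring can move the number a great deal in either direction. The expectation for compound 4 is therefore a wide one, with little reason to favour a stronger or weaker result beyond the scatter; the step is estimated as a 1.1-fold higher number from compound 3 to compound 4 (0.02 log units; within the scatter). Compound 4 is estimated to give about 40000 nM, between 8000 nM and 200000 nM.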

Compound 4, inhibition constant: 420000 nM
Compound 4: the middle estimate sits 11-fold (1.02 log units) below what was measured; measured number outside the range, above it.
By their numbers in this assay, from the lowest: compound 1; then compound 3; then compound 2; then compound 4.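

In this assay, within the data shown here, hydroxy in place of phenyl on this aromatic carbon, para to a large group, is the first swap of one kind of group for another, and it gives an 11-fold higher number from compound 3 to compound 4 (1.04 log units; beyond the scatter) in the weaker direction. Compared with the two dichlorophenyl compounds, the 4-hydroxyphenyl end gives a 3.8-fold higher number from compound 2 to compound 4 (0.58 log units; beyond the scatter) and a 58-fold higher number from compound 1 to compound 4 (1.76 log units; beyond the scatter) as well, which makes compound 4 the weakest inhibitor of the four. Nothing measured here explains this loss.

The step from compound 3 to compound 4 removes a ring and adds a hydroxy in one move, so the two changes cannot be told apart. A methoxy group or an amine on the same carbon would be a further test of what this position accepts.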